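This account rests on a few compounds, and the source may have more. Where it says the series, first, only, none or still open, it means among the compounds named here.

The enzyme nicotinamide phosphoribosyltransferase can be switched on by small molecules, and the compounds here were compared for that effect in an assay on isolated protein for activation of Nicotinamide phosphoribosyltransferase (Homo sapiens); on this read-out higher numbers stand for an effect only at larger amounts of compound and lower numbers for an effect already at smaller amounts. Compound 1 `CCN(C1CCCC1)S(=O)(=O)c1ccc(NC(=O)NCc2ccncc2)cc1` gives 60 nM in this assay. Compound 3 `O=C(NCc1cnco1)Nc1ccc(S(=O)(=O)c2ccccc2)cc1` gives 77 nM, a number that lies within the usual scatter of the value for compound 1, so the two cannot be told apart. Compound 2 `CCOC(=O)c1ccc(NC(=O)OCc2ccncc2)cc1` gives 10800 nM, far beyond the scatter of both. Compound 1 therefore sits at the low end of the three numbers, with compound 3 close beside it and compound 2 well away.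

Compound 4 `O=C(NCc1ccncc1)Nc1ccc(S(=O)(=O)c2ccc(Cl)cc2)cc1` has not yet been measured. It differs from compound 1 in a single place: 4-chlorophenyl in place of cyclopentyl(ethyl)amino on a sulfonyl sulfur. Compound 3 also carries a six-membered aromatic ring of carbon only on its sulfonyl sulfur, and because compound 3 gives 77 nM that kind of group is known to go together with a low number in this assay. The step from compound 1 to compound 4 is thus expected to be small, no change at the digits printed from compound 1 to compound 4 (within the scatter), in no particular direction and within the scatter. Compound 4 is estimated at 60 nM, with a range from 25 nM to 150 nM.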

Compound 4, half-maximal effective concentration: 126 nM
Compound 4: the middle estimate sits 2.1-fold (0.32 log units) below what was measured; the range from low to high includes it.
By their numbers in this assay, from the lowest: compounds 1, 3 and 4 (each within the scatter of the next, the first and the last beyond it); then compound 2.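

On a sulfonyl sulfur whose other neighbour is an aromatic carbon, putting 4-chlorophenyl in place of cyclopentyl(ethyl)amino gives, in this assay, a 2.1-fold higher number from compound 1 to compound 4 (0.32 log units; beyond the scatter), a modest step that lies just beyond the usual scatter. For the compounds shown here, this is the first direct look at this position, and it shows that the number moves only modestly even though the group that leaves holds a nitrogen and a five-membered non-aromatic ring of carbon only, while the group that enters holds a chlorine and a six-membered aromatic ring of carbon only. Nothing among the data shown explains the direction or size of this step.

On these data alone, the swap changes the ring and adds the chlorine in one move, so it remains open whether a plain phenyl on the same sulfur, in the core of compound 1, would give a number closer to that of compound 1 or to that of compound 4. Also open, as far as these compounds go, is how a methyl group or a longer alkyl chain on the sulfur, or a piperidine ring joined through its nitrogen, would fare at this position.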